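This account rests on a few compounds, and the source may have more. Where it says the series, first, only, none or still open, it means among the compounds named here.

In a functional assay on HeLa cells (Homo sapiens) for antiproliferative activity, read by MTT assay, with a stated time of 72 h (on this read-out lower numbers stand for stronger inhibition and higher numbers for weaker inhibition), compound 1 (`COc1cc(-c2nc(C)sc2-c2ccc(C)cc2)cc(OC)c1OC`) gives 1100 nM and compound 2 (`COc1cc(-c2nc(C)sc2-c2ccc(C(F)(F)F)cc2)cc(OC)c1OC`) gives 3830 nM, the higher of the two numbers and so the weaker result. Compound 3 (`CCOc1ccc(-c2sc(C)nc2-c2cc(OC)c(OC)c(OC)c2)cc1`) carries ethoxy in place of trifluoromethyl on an aromatic carbon. Among the measured compounds shown here, only one measured step bears on this, a 3.5-fold higher number from compound 1 to compound 2 (0.54 log units; beyond the scatter), seen when trifluoromethyl replaced methyl. For the measured compounds named here, no ethoxy compound has been measured, so this guide is thin, but removing trifluoromethyl is expected to give a lower number in this assay, by a somewhat larger step. The estimated change is a 13-fold lower number from compound 2 to compound 3 (1.11 log units; beyond the scatter). For compound 3 the expected value is 300 nM, within an estimated range of 40 nM to 2000 nM.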

Compound 3, half-maximal inhibitory concentration: 1870 nM
For compound 3 the middle estimate is 6.2-fold (0.79 log units) below the measured one; the range from low to high includes it.
By their numbers in this assay, from the lowest: compounds 1 and 3 (each within the scatter of the next); then compound 2.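

Swapping trifluoromethyl for ethoxy at this position gives a 2.0-fold lower number from compound 2 to compound 3 (0.31 log units; beyond the scatter), so the weaker result of compound 2 is not shared by every replacement of methyl. Ethoxy gives a 1.7-fold higher number from compound 1 to compound 3 (0.23 log units; within the scatter), which means the position accepts either group without a clear difference in this assay. No measurement here explains why trifluoromethyl differs from the other two groups.

Going by these compounds, it remains open whether the oxygen of ethoxy matters, which a propyl group could help test. A longer chain such as butoxy, or an amine here, might also behave differently.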